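The source may report more compounds than this note shows. Statements on the series, on what has been measured and on what is new or still open speak of the compounds shown alone.

In a functional assay on HCT-116 cells (Homo sapiens) for inhibition, read by CCK-8 assay, with a stated time of 48 h (on this read-out higher numbers stand for weaker inhibition and lower numbers for stronger inhibition), compound 3 `COc1cc(-c2ccnc3cc(-c4ccc(C(F)(F)F)cc4)nn23)cc(OC)c1OC` gives 1860 nM, the highest of the three numbers, against compound 1 `COc1cc(-c2ccnc3cc(-c4ccc(C)c(C)c4)nn23)cc(OC)c1OC` at 261 nM and compound 2 `COc1cc(-c2ccnc3cc(-c4ccc5c(ccn5C)c4)nn23)cc(OC)c1OC` at 39 nM. Compound 4 `COc1cc(-c2ccnc3cc(-c4ccc(-c5cnn(C)c5)cc4)nn23)cc(OC)c1OC` carries 1-methyl-1H-pyrazol-4-yl in place of trifluoromethyl on an aromatic carbon. Among the measured compounds shown here, no measured step makes this exact exchange. The nearest evidence is a 7.1-fold higher number from compound 1 to compound 3 (0.85 log units; beyond the scatter) and the larger 48-fold higher number from compound 2 to compound 3 (1.68 log units; beyond the scatter), both of which arrive at compound 3 and end on its high number. Compound 2, whose 1-methyl-1H-indol-5-yl also holds a methylated nitrogen ring, shows how low the series can reach at 39 nM. A modest drop is therefore expected, and the estimated change is a 7.4-fold lower number from compound 3 to compound 4 (0.87 log units; beyond the scatter). For compound 4 the expected value is 250 nM, within a range of 50 nM to 1200 nM.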

Compound 4, half-maximal inhibitory concentration: 2110 nM
The estimate for compound 4 lay 8.4-fold (0.93 log units) below the measured number; measured number outside the range, above it.
By their numbers in this assay, from the lowest: compound 2; then compound 1; then compounds 3 and 4 (each within the scatter of the next).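

In this assay, placing 1-methyl-1H-pyrazol-4-yl instead of trifluoromethyl on the aromatic carbon para to a large group gives a 1.1-fold higher number from compound 3 to compound 4 (0.05 log units; within the scatter) and so separates the two groups by no more than the scatter. At this position, then, exchanging a group without a ring for a five-membered aromatic ring with 2 hetero atoms leaves the number unchanged. Nothing given here accounts for this result. The compounds shown leave open whether an amine or a carboxylic acid at this position would move the number.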